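Aryl substituent exchange on the alkyne amide thiazolidine series

The source may hold more compounds than are shown below. What is called first, only, known or untested is meant among the compounds shown, and "the series" means these compounds.

Going by the values given here, compound 1 `C#CC(=O)N1C(c2ccc(C#N)cc2)SC[C@@H]1C(=O)OCC` gives 2600 nM in a functional assay on Huh-7 cells (Homo sapiens) for inhibition, read by sulforhodamine B assay (on this read-out lower numbers stand for stronger inhibition and higher numbers for weaker inhibition), and stands highest of the three numbers known so far. Compound 2 `C#CC(=O)N1C(CCCCC)SC[C@@H]1C(=O)OCC` gives 1800 nM in this assay, which sits within the scatter of compound 1. Compound 3 `C#CC(=O)N1C(CCCC)SC[C@@H]1C(=O)OCC` gives 500 nM in this assay, beyond the scatter from compound 1. Among the compounds with values here, the single step with one point of difference, a 3.6-fold lower number from compound 2 to compound 3 (0.56 log units; beyond the scatter), concerns shortening of a saturated chain on the core and carries no information about the aromatic ring of compound 1.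

Within the data shown here, compound 4 `C#CC(=O)N1C(c2ccc(OC)cc2)SC[C@@H]1C(=O)OCC` is the next compound to be measured. methoxy in place of cyano on an aromatic carbon No measured step bears on this change: the only step in the set, a 3.6-fold lower number from compound 2 to compound 3 (0.56 log units; beyond the scatter), alters a saturated chain and not an aromatic substituent, so the data give no direction for replacing one acceptor-bearing group by another on the aromatic ring. The expectation is therefore a number close to that of compound 1, with the step of a 1.3-fold lower number from compound 1 to compound 4 (0.11 log units; within the scatter) expected to fall within the scatter. Compound 4 is estimated at 2000 nM in this assay, with a range from 600 nM to 7000 nM to cover the absence of any relevant comparison.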

Compound 4, half-maximal inhibitory concentration: 1400 nM
For compound 4 the middle estimate is 1.4-fold (0.15 log units) above the measured one; the range from low to high includes it.
By their numbers in this assay, from the lowest: compound 3; then compounds 4, 2 and 1 (each within the scatter of the next).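

Cyano to methoxy on an aromatic carbon, para to a large group, is the first change at this position that can be read in this assay (a 1.9-fold lower number from compound 1 to compound 4 (0.27 log units; within the scatter)). The step stays within the scatter, so the read-out does not separate the two groups, and compound 1 and compound 4 alone give no direction for substitution at this aromatic carbon. Nothing available bears on what lies behind this outcome.

Open at this position is whether any other group, such as an amine, a carboxylic acid, a chlorine atom or plain hydrogen in place of the methoxy, would move the number beyond the scatter, and whether the same aromatic carbon responds differently to a longer alkoxy chain. Also open, as far as these compounds go, is whether the lack of separation between cyano and methoxy holds when other parts of the shared core change, for example with a carboxylic acid in place of the ethyl ester.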